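Adding a Silicon-Bearing Group to Compound 2

This account rests on a few compounds, and the source may have more. Where it says the series, first, only, none or still open, it means among the compounds named here.

Measured in a functional assay on K562 cells (Homo sapiens) for antiproliferative activity, read by MTT assay, with a stated time of 5 days; a higher number here means a weaker inhibitor, a lower number a stronger inhibitor:
Compound 1 `COc1ccc(C=C(C(=O)c2cc(OC)c(OC)c(OC)c2)c2ccccc2O)cc1`: 240000 nM
Compound 2 `COc1ccc(/C=C(/C(=O)c2cc(OC)c(OC)c(OC)c2)c2ccccc2O)cc1`: 370000 nM

Compounds 1 and 2 cannot be told apart on these numbers. The change between them is a 1.5-fold higher number from compound 1 to compound 2 (0.19 log units; within the scatter), and their only difference is the fact that one of compounds 1 and 2 is drawn with a defined configuration and the other without, at the place where they differ. Compound 2 therefore stands level with compound 1, and both values are very large for an inhibitor in this assay.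

Compound 3 `COc1ccc(/C=C(/C(=O)c2cc(OC)c(OC)c(OC)c2)c2ccccc2O)cc1O[Si](C)(C)C(C)(C)C` keeps the core of compound 2 and alters one place: a group of 8 heavy atoms (6 carbon, 1 oxygen, 1 silicon; no ring) in place of a hydrogen atom, on an aromatic carbon. The new group sits ortho to a methoxy group.

Within the data shown here, no measurement yet tests a change at this place. Among the measured compounds shown here, the only measured step, a 1.5-fold higher number from compound 1 to compound 2 (0.19 log units; within the scatter), concerns the way a double bond is drawn, so it offers no guide to this much larger change. With nothing pointing either way, no step beyond the scatter is expected in this assay, although the uncertainty is wide. The estimate means a 1.2-fold lower number from compound 2 to compound 3 (0.09 log units; within the scatter), an expected step and not a measured one. Compound 3 is expected at about 300000 nM, with an estimated range of 60000 nM to 1000000 nM.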

Compound 3, half-maximal inhibitory concentration: 380000 nM
Compound 3: the middle estimate sits 1.3-fold (0.10 log units) below what was measured, within the range that was stated.
By their numbers in this assay, from the lowest: compounds 1, 2 and 3 (each within the scatter of the next).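

In this assay, putting the silicon-bearing group on an aromatic carbon, ortho to a methoxy group and meta to a large group, in place of a hydrogen atom gives a 1.0-fold higher number from compound 2 to compound 3 (0.01 log units; within the scatter) on the way to the new compound. Compounds 1 and 2 differ only in how a double bond is drawn, so they said nothing about this position; here the position carries a far bigger group than a hydrogen atom, compound 3 stands level with compound 2, and the number of compound 3 at 380000 nM is still very large for an inhibitor. No measurement shown gives a reason for this outcome.

On these data alone, one substitution cannot show a trend, so it remains open whether a free hydroxyl group, an amine, a carboxylic acid or a longer carbon chain at this same place would also stay level with compound 2. As far as these compounds go, all three numbers are very large, and it also remains open whether the silicon-bearing group would leave the number unchanged on a related compound with a much lower starting value.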